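Replacing the cyano group of compound 3 with hydrogen

The source may hold more compounds than are shown below. What is called first, only, known or untested is meant among the compounds shown, and "the series" means these compounds.

In an ADME assay on microsomes from liver (Rattus norvegicus) for metabolic stability (on this read-out lower numbers stand for slow clearance and higher numbers for fast clearance), compound 1 (`N#Cc1ccccc1Oc1ccc([C@H]2CC[C@@H](C(N)=O)N2)cc1`) gives 1.8 mL.min-1.g-1, compound 2 (`CN1[C@@H](c2ccc(OCc3ccccc3F)cc2)CC[C@H]1C(N)=O`) gives 1.3 mL.min-1.g-1 and compound 3 (`N#Cc1ccccc1COc1ccc([C@H]2CC[C@@H](C(N)=O)N2)cc1`) gives 1.4 mL.min-1.g-1. Compound 3 is not separated from either neighbour, as all three numbers lie within the scatter of one another.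

Compound 4 (`NC(=O)[C@@H]1CC[C@H](c2ccc(OCc3ccccc3)cc2)N1`) has hydrogen in place of cyano on an aromatic carbon, ortho to a large group: hydrogen in place of cyano on an aromatic carbon. Going by the values given here, no measured pair isolates this change, so the direction is poorly defined. The expected 1.3-fold higher number from compound 3 to compound 4 (0.11 log units; within the scatter) stays within the scatter, with only a slight lean toward faster clearance. For compound 4 the estimated value is 1.8 mL.min-1.g-1, with an expected range of 0.9 mL.min-1.g-1 to 3.6 mL.min-1.g-1.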

Compound 4, intrinsic clearance in microsomes: 0.5 mL.min-1.g-1
The estimate for compound 4 lay 3.6-fold (0.56 log units) above the measured number, outside the stated range (below it).
By their numbers in this assay, from the lowest: compound 4; then compounds 2, 3 and 1 (each within the scatter of the next).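

In this assay, going by these compounds alone, 2-cyanophenyl to phenyl gives a 2.8-fold lower number from compound 3 to compound 4 (0.45 log units; beyond the scatter), the first step to lie beyond the scatter. The place ortho to a large group therefore responds to this change, with hydrogen on the side of slower clearance. No measurement here explains the step.

From the compounds shown here alone, it remains open whether a methoxy group or a chlorine atom at this place would read nearer compound 3 or compound 4. Going by these compounds, whether the same change gives a similar step in the setting of compound 1 also remains open.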